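Carbamate nitrogen substituent: benzyl to phenyl

The compounds below may be only part of what the source reports. "The series", "measured", "known", "first", "only" and "open" are said of these compounds alone.

In a functional assay on MDA-MB-231 cells (Homo sapiens) for antiproliferative activity, read by MTT assay, with a stated time of 96 h (on this read-out higher numbers stand for weaker inhibition and lower numbers for stronger inhibition), compound 1 `CC(C)=CCC/C(C)=C/CC/C(C)=C/CC[C@]1(C)CCc2cc(OC(=O)NS(=O)(=O)c3ccc(Cl)cc3)cc(C)c2O1` gives only the limit > 10000 nM. Compound 2 `CC(C)=CCC/C(C)=C/CC/C(C)=C/CC[C@]1(C)CCc2cc(OC(=O)NCc3ccccc3)cc(C)c2O1` likewise gives only the limit > 10000 nM in this assay. The step that the two limits leave unreadable from compound 1 to compound 2 has no readable size, since (the limit of > 10000 nM in this assay, at which 2 of the 2 values shown sit). Compound 3 `CC(C)=CCC/C(C)=C/CC/C(C)=C/CC[C@]1(C)CCc2cc(OC(=O)Nc3ccccc3)cc(C)c2O1` differs from compound 2 by phenyl in place of benzyl on an amide-type nitrogen. Among the measured compounds shown here, no measured step in this assay bears on this change, so no direction beyond the scatter can be expected. Compound 3 is expected to remain at the limit, the step of a number no higher from compound 2 to compound 3 (the limit leaves the size open) being estimated as none readable. For compound 3 the estimate in this assay is 10000 nM, between 3000 nM and 30000 nM.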

Compound 3, half-maximal inhibitory concentration: > 10000 nM
Compound 3: a limit, no number (the forecaster's own chance of this, stated with the estimate: 75%); the middle value sits exactly at the limit.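

No step among compound 1, compound 2 and compound 3 can be read in this assay, because each gives a limit and not a number: the limit of > 10000 nM in this assay, at which 3 of the 3 values shown sit.

The compounds shown leave open how these three substituents on the amide-type nitrogen rank against one another.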